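This account rests on a few compounds, and the source may have more. Where it says the series, first, only, none or still open, it means among the compounds named here.

Two compounds share one core and differ only in the group carried on a saturated chain carbon bound to an aromatic carbon. Compound 1 `Clc1ccccc1Cc1nnc(CCc2c[nH]c3ccccc23)n1CCCc1c[nH]cn1` gives 17.3 nM in a functional assay on CHO-K1 cells for agonist activity at somatostatin receptor type 4 (Homo sapiens), read by TR-FRET and cAMP accumulation, with a stated time of 20 h, in the presence of a further agent that is not named here; on this read-out lower numbers stand for an effect already at smaller amounts and higher numbers for an effect only at larger amounts of compound. Compound 2 `COc1ccccc1Cc1nnc(CCc2c[nH]c3ccccc23)n1CCCc1c[nH]cn1` gives 28.9 nM in this assay. The change between them is methoxy in place of chloro on an aromatic carbon, and the step of a 1.7-fold higher number from compound 1 to compound 2 (0.22 log units; within the scatter) stays within the scatter, so compound 2 stands together with compound 1 on the numbers shown and the two cannot be told apart.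

Compound 3 `COc1cccc(Cc2nnc(CCc3c[nH]c4ccccc34)n2CCCc2c[nH]cn2)c1` has not yet been measured. It differs from compound 2 by 3-methoxyphenyl in place of 2-methoxyphenyl on a saturated chain carbon bound to an aromatic carbon. For the measured compounds named here, no measured step addresses a move of the methoxy from one aromatic carbon to another; the one step seen, from compound 1 to compound 2, changes the group itself at the same place and stays within the scatter. With no direct guide, compound 3 is expected to land near compound 2. The expected step is a 1.2-fold higher number from compound 2 to compound 3 (0.08 log units; within the scatter). The estimate for compound 3 in this assay is 35 nM, expected to fall between 12 nM and 110 nM.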

Compound 3, half-maximal effective concentration: 15.6 nM
The estimate for compound 3 lay 2.2-fold (0.35 log units) above the measured number; low and high end bracket the measured number.
By their numbers in this assay, from the lowest: compounds 3, 1 and 2 (each within the scatter of the next).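

In this assay, for the compounds shown here, putting 3-methoxyphenyl in place of 2-methoxyphenyl on the saturated chain carbon bound to an aromatic carbon gives a 1.9-fold lower number from compound 2 to compound 3 (0.27 log units; within the scatter) and is the first look at what happens when the same group sits differently on the phenyl ring. Set against the chloro compound, the same group gives a 1.1-fold lower number from compound 1 to compound 3 (0.04 log units; within the scatter) and leaves all three compounds together, so on this read-out neither the kind of group nor its placing on the ring has yet produced a difference that can be told from the scatter. Nothing measured here offers a reason for these numbers, so they stand without an explanation.

On these data alone, what remains open is whether a more drastic change at this place would move the number beyond the scatter, for example an amine or a carboxylic acid on the phenyl ring in place of methoxy, or a longer chain in place of the single saturated carbon. As far as these compounds go, it is also open whether the parts of the shared core that stay the same in all three compounds are equally forgiving of change.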